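The source may report more compounds than this note shows. Statements on the series, on what has been measured and on what is new or still open speak of the compounds shown alone.

Measured so far: compound 1 `COc1cc(-c2cnn3cc(OC)c(-c4cnn(C)c4)nc23)ccn1` with 530 nM in an assay on isolated protein for inhibition of activin receptor type-2A (Homo sapiens), read by 33P incorporation, with a stated time of 20 min, in the presence of a further agent that is not named here; on this read-out higher numbers stand for weaker inhibition and lower numbers for stronger inhibition; compound 2 `COc1cc(-c2cnn3cc(OC)c(C)nc23)ccn1` with 1200 nM.

For the measured compounds named here, compound 1 holds the lowest number of the two, and the only measured step runs a 2.3-fold higher number from compound 1 to compound 2 (0.35 log units; beyond the scatter). Compound 3 `COc1cn2ncc(-c3ccnc(OC4CC4)c3)c2nc1-c1cnn(C)c1` differs from compound 1 by cyclopropyl in place of methyl on an oxygen on an aromatic ring. Going by the values given here, no measured step touches that oxygen; the one step known concerns a different position, so it offers no guide for the direction here, only a sense that single changes on this core have been modest. Compound 3 is therefore expected to stay near compound 1, at an estimated 450 nM, within 150 nM to 1500 nM. The expected step is a 1.2-fold lower number from compound 1 to compound 3 (0.07 log units; within the scatter).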

Compound 3, half-maximal inhibitory concentration: 860 nM
Beside the measured number, compound 3's estimate is 1.9-fold (0.28 log units) below it, and the stated range covers the measured number.
By their numbers in this assay, from the lowest: compounds 1, 3 and 2 (each within the scatter of the next, the first and the last beyond it).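

For the compounds shown here, replacing methyl with cyclopropyl on this oxygen gives the first reading at this position (a 1.6-fold higher number from compound 1 to compound 3 (0.21 log units; within the scatter)). The change from methoxy to cyclopropyloxy therefore adds a three-membered ring of carbon without moving the number beyond the scatter. No supporting measurement bears on this result.

The compounds shown leave open whether a longer chain or an amine-bearing chain on this oxygen would move the number beyond the scatter. They also leave open whether cyclopropyloxy would read the same with methyl in place of 1-methyl-1H-pyrazol-4-yl.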